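The compounds below may be only part of what the source reports. "The series", "measured", "known", "first", "only" and "open" are said of these compounds alone.

Compound 1 `CC[C@@H]1CN(c2scnc2-c2nc3ccccc3[nH]2)CCN1C(=O)Cn1cnc2cccnc21`: 604 nM
Compound 2 `CCOc1ncc(-c2nc(C(F)(F)F)sc2N2CCN(C(=O)Cn3ccc4cccnc43)[C@H](C)C2)cn1`: 47 nM

Of the compounds shown here, two have been measured in a functional assay on U2OS cells for antagonist activity at C-X-C chemokine receptor type 3 (Homo sapiens), read by beta-arrestin recruitment; a lower number here means a stronger inhibitor, a higher number a weaker inhibitor. Compound 2 gives 47 nM, the lower of the two numbers, while compound 1 gives 604 nM, and the gap between them lies beyond the usual scatter of repeated measurements, so compound 2 is the stronger inhibitor of the pair. Compound 3 `CCOc1ncc(-c2nc(C(F)(F)F)sc2N2CCN(C(=O)Cn3cc(Cl)cn3)[C@H](C)C2)cn1` has not been measured. It differs from compound 2 in one place: a group of 6 heavy atoms (3 carbon, 2 nitrogen, 1 chlorine; one five-membered aromatic ring with 2 hetero atoms) in place of a group of 9 heavy atoms (7 carbon, 2 nitrogen; one five-membered aromatic ring with 1 hetero atom, one six-membered aromatic ring with 1 hetero atom), on a saturated chain carbon bound to a carbonyl carbon. Within the data shown here, no measured pair shows this exchange directly, so its effect is not known from the data. The entering group is the smaller of the two and brings no six-membered aromatic ring, so a modest weakening is expected; the estimated step for compound 3 in this assay is a 3.2-fold higher number from compound 2 to compound 3 (0.50 log units; beyond the scatter). For compound 3 the estimated value is 150 nM, with a range from 40 nM to 600 nM.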

Compound 3, half-maximal inhibitory concentration: 272 nM
Estimate against measurement, compound 3: 1.8-fold (0.26 log units) below, within the range that was stated.
By their numbers in this assay, from the lowest: compound 2; then compound 3; then compound 1.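

In this assay, replacing the group with one five-membered and one six-membered aromatic ring by 4-chloro-1H-pyrazol-1-yl gives a 5.8-fold higher number from compound 2 to compound 3 (0.76 log units; beyond the scatter). Among these compounds, this is the first direct reading of this position, on a saturated chain carbon bound to a carbonyl carbon, and it shows that the group held there changes the result by more than the scatter, with everything else in the molecule kept the same. No measurement is available to explain why the number rises.

As far as these compounds go, a single exchange also changes several things at once: the six-membered aromatic ring goes, and a chlorine and a different five-membered ring arrive, so the contribution of each remains open. A pyrazole carrying a methyl group or a nitrile in place of the chlorine would help separate these contributions.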